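The compounds below may be only part of what the source reports. "The series", "measured", "known", "first", "only" and "open" are said of these compounds alone.

In a physicochemical assay for lipophilicity, read by HPLC, at pH 7.4 (a lower number here means a more polar compound, a higher number a more lipophilic compound), compound 2 `CC(C)Cc1cc2oc(=O)n(CCC(=O)O)c2cc1Cl` stands highest of the two numbers at 3.03, while compound 1 `CCc1cc2oc(=O)n(CCC(=O)O)c2cc1Cl` gives 1.94. The next compound, compound 3 `O=C(O)CCn1c(=O)oc2cc(OCc3ccccn3)c(Cl)cc21`, differs from compound 2 as follows: (pyridin-2-yl)methoxy in place of isobutyl on an aromatic carbon. In words, (pyridin-2-yl)methoxy replaces isobutyl on an aromatic carbon, ortho to a chloro group.

Among the compounds with values here, only one measured step bears on this change: a number 1.09 log units higher from compound 1 to compound 2 (beyond the scatter). That step is large and beyond the scatter, but it covers only a change within the alkyl chain. Within the data shown here, no measured compound carries the entering group, so the comparison is indirect. Going by a number 1.09 log units higher from compound 1 to compound 2 (beyond the scatter), a downward step of similar size is expected in this assay, and the expected step is a number 0.93 log units lower from compound 2 to compound 3 (beyond the scatter). For compound 3 the estimated value is 2.1, with an expected range from 1.5 to 2.7.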

Compound 3, distribution coefficient: 1.32
Estimate against measurement, compound 3: 0.78 log units above, outside the stated range (below it).
By their numbers in this assay, from the lowest: compound 3; then compound 1; then compound 2.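

On an aromatic carbon ortho to a chloro group, replacing an alkyl group with (pyridin-2-yl)methoxy reverses the direction seen so far in this assay: isobutyl gives way with a number 1.71 log units lower from compound 2 to compound 3 (beyond the scatter) and ethyl with a number 0.62 log units lower from compound 1 to compound 3 (beyond the scatter) as the second reading. Among these three compounds, the number therefore does not follow substituent size: it rises from ethyl to isobutyl, but compound 3 goes against that trend, with the most heavy atoms at this position and the lowest value. Nothing available accounts for this drop.

The compounds shown do not separate the contributions of the ring nitrogen, the ether oxygen and the aromatic ring within the entering group. Benzyloxy, methoxy or an amine at this position would help divide the step among those parts.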